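Swapping thiophen-2-yl for 4-methylphenyl in an inactive series

A few compounds are considered here, and "the series" means these few. Any claim that something is new, unique, unknown or untested is made for them only; others in the source may bear on it.

Three compounds from this series were tested in a functional assay on HL-60 cells (Homo sapiens), read by calcium flux; on this read-out higher numbers stand for an effect only at larger amounts of compound and lower numbers for an effect already at smaller amounts. Compound 1, `COc1cccc(Cc2cc(C3CCCCC3)nn(CC(=O)Nc3ccc(Br)cc3)c2=O)c1`, gives only a limit, > 50000 nM. Compound 2, `COc1ccc(Cc2cc(-c3cccs3)nn(CC(=O)Nc3ccc(Br)cc3)c2=O)cc1`, likewise gives only a limit, > 50000 nM. Compound 3, `COc1cccc(Cc2cc(-c3ccc(Cl)cc3)nn(CC(=O)Nc3ccc(F)cc3)c2=O)c1`, again gives only a limit, > 50000 nM. Compound 2 therefore stands at the same limit as the two others, as summarised by the limit of > 50000 nM in this assay, at which 3 of the 3 values shown sit; no number separates any of them, so nothing can be said about order among them.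

Compound 4, `COc1ccc(Cc2cc(-c3ccc(C)cc3)nn(CC(=O)Nc3ccc(Br)cc3)c2=O)cc1`, has not yet been measured in this assay. It differs from compound 2 by 4-methylphenyl in place of thiophen-2-yl on an aromatic carbon. For the measured compounds named here, no step between two measured compounds carries a number, so there is no measured change to build on. With all three known values sitting at the limit, the step from compound 2 to compound 4 is expected to be a step that the limit leaves unreadable from compound 2 to compound 4, that is, none beyond the scatter and most likely again a limit rather than a number. For compound 4 in this assay the estimate is 80000 nM, between 20000 nM and 300000 nM.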

Compound 4, half-maximal effective concentration: > 50000 nM
Compound 4: only a limit was reported; the forecaster's own chance of this, stated with the estimate: 85%; the middle value lies beyond the limit too.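

Compound 2 and compound 4 both give only a limit in this assay, so no step can be read between them: the limit of > 50000 nM in this assay, at which 4 of the 4 values shown sit. The compounds shown leave open whether any change to this series would give a measurable value in this assay.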